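Chlorophenyl for chloropyridinyl: half-life notes on compound 3

The source may report more compounds than this note shows. Statements on the series, on what has been measured and on what is new or still open speak of the compounds shown alone.

Measured so far in an ADME assay on microsomes from liver (Homo sapiens) for metabolic stability, read by LC-MS; a higher number here means that the compound lasts longer, a lower number that the compound disappears faster
- compound 1 `Cc1nc(C)c(C(=O)Nc2ccc(F)c(-c3nc4ncc(-c5cccnc5Cl)cn4n3)c2)o1` gives > 1.5 h (a limit)
- compound 2 `O=C(Nc1ccc(F)c(-c2nc3ncc(-c4cccnc4F)cc3[nH]2)c1)N1CCCC1` gives > 1.5 h (a limit)

Both entries are limits of the assay and not numbers. The series offers the limit of > 1.5 h in this assay, at which 2 of the 2 values shown sit, as its only reference point, and compound 1 has no exact value there.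

Compound 3 `Cc1nc(C)c(C(=O)Nc2ccc(F)c(-c3nc4ncc(-c5ccccc5Cl)cn4n3)c2)o1` keeps the core of compound 1 and carries 2-chlorophenyl in place of 2-chloropyridin-3-yl on an aromatic carbon with nothing else altered. Among the measured compounds shown here, no measured pair shows this change, so any expectation rests on the change alone and stays loose. A modest move toward a shorter half-life in this assay is expected, of a size close to the usual scatter, and a further limit is about as likely as a number. The expected step is an at least 1.2-fold lower number from compound 1 to compound 3 (0.09 log units; that floor lies within the scatter) on this estimate. Compound 3 is expected at 1.2 h with an estimated range of 0.5 h to 2 h for its half-life.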

Compound 3, half-life in the Homo sapiens assay: > 1.5 h
Compound 3: only a limit was reported; the forecaster's own chance of this, stated with the estimate: 50%; middle value at least 1.2-fold (0.09 log units) from the limit.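

In the Homo sapiens assay compound 1 gives > 1.5 h as a limit and not a number. In the Homo sapiens assay compound 3 gives > 1.5 h as a limit and not a number. No step between them can be read: the limit of > 1.5 h in the Homo sapiens assay, at which 3 of the 3 values shown sit.

In a physicochemical assay for solubility, read by LC-MS, in phosphate buffer, at pH 7.4, tested at 50 uM (on this read-out higher numbers stand for higher solubility and lower numbers for lower solubility), compound 1 gives 3840 nM and compound 3 gives 1980 nM and these two values lie within the scatter of each other.

From the compounds shown here alone, the actual half-lives of compound 1 and compound 3 remain open, as does whether 2-chlorophenyl in place of 2-chloropyridin-3-yl changes the half-life at all.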